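Replacing 3-methylphenyl with 4-chlorophenyl on a shared core

This account rests on a few compounds, and the source may have more. Where it says the series, first, only, none or still open, it means among the compounds named here.

Three compounds with the same core, measured in a functional assay on MCF7 cells (Homo sapiens) for antiproliferative activity, read by MTT assay, with a stated time of 72 h; on this read-out lower numbers stand for stronger inhibition and higher numbers for weaker inhibition:

- compound 1 `CCOc1ccc(-c2ccc3ncn(-c4cc(OC)c(OC)c(OC)c4)c3c2)cc1` gives 1710 nM
- compound 2 `COc1cc(-n2cnc3ccc(-c4cccc(Cl)c4)cc32)cc(OC)c1OC` gives 3120 nM
- compound 3 `COc1cc(-n2cnc3ccc(-c4cccc(C)c4)cc32)cc(OC)c1OC` gives 360 nM

Of these three, compound 3 has the lowest number, and its steps to both others lie beyond the scatter. Compound 4 `COc1cc(-n2cnc3ccc(-c4ccc(Cl)cc4)cc32)cc(OC)c1OC` has not been measured yet. It carries 4-chlorophenyl in place of 3-methylphenyl on an aromatic carbon.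

Among the compounds with values here, two measured steps bear most directly on this change, and both end at compound 3. One is a 4.8-fold lower number from compound 1 to compound 3 (0.68 log units; beyond the scatter), and it starts from 4-ethoxyphenyl. The other is an 8.7-fold lower number from compound 2 to compound 3 (0.94 log units; beyond the scatter), and it starts from 3-chlorophenyl, which has chloro in common with compound 4. The remaining step, a 1.8-fold higher number from compound 1 to compound 2 (0.26 log units; within the scatter), does not separate those two groups. Within the data shown here, no measurement yet compares 3-chlorophenyl with 4-chlorophenyl directly, so this reasoning is indirect.

Read in reverse, both steps point to a modest rise in this assay on leaving 3-methylphenyl. The estimated step is a 4.2-fold higher number from compound 3 to compound 4 (0.62 log units; beyond the scatter), which would lie beyond the scatter. Compound 4 is expected at an estimated 1500 nM, with an expected range of 450 nM to 4500 nM.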

Compound 4, half-maximal inhibitory concentration: 1320 nM
For compound 4 the middle estimate is 1.1-fold (0.06 log units) above the measured one, within the range that was stated.
By their numbers in this assay, from the lowest: compound 3; then compounds 4, 1 and 2 (each within the scatter of the next, the first and the last beyond it).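

In this assay, within the data shown here, the place of the chloro matters, since 4-chlorophenyl in place of 3-chlorophenyl gives a 2.4-fold lower number from compound 2 to compound 4 (0.37 log units; beyond the scatter) and this is the first direct comparison of the two chlorophenyl groups. Even so, shifting the chloro does not bring the number down to that of compound 3: the change from 3-methylphenyl gives a 3.7-fold higher number from compound 3 to compound 4 (0.56 log units; beyond the scatter) and compound 3 keeps the lowest number, with its steps to all three other compounds beyond the scatter. Chloro in place of ethoxy gives a 1.3-fold lower number from compound 1 to compound 4 (0.11 log units; within the scatter) so 4-chlorophenyl and 4-ethoxyphenyl cannot be told apart in this assay, and no measurement at hand accounts for any of these differences.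

Among these compounds, with only one methyl compound among the four, it remains open whether the low number belongs to methyl itself or to methyl in the 3-methylphenyl arrangement, a question that 4-methylphenyl could settle. Going by these compounds, how this position would respond to a phenyl ring carrying an amine or a carboxylic acid also remains open.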